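A few compounds are considered here, and "the series" means these few. Any claim that something is new, unique, unknown or untested is made for them only; others in the source may bear on it.

Compound 3 `Cc1cc(NC(=O)Nc2cc(C(C)(C)C)on2)ccc1Nc1ncnc2c1OCCN2` gives 85 nM in an assay on isolated protein for inhibition of proto-oncogene tyrosine-protein kinase receptor Ret variant V804L (Homo sapiens), read by 33P incorporation, with stated times of 15 min and 40 min (a higher number here means a weaker inhibitor, a lower number a stronger inhibitor), the highest of the three numbers in hand. Compound 1 `CC(C)(C)c1cc(NC(=O)Nc2ccc(Nc3ncnc4c3OCCN4)cc2)no1` gives 58 nM in this assay, and compound 2 `CC(C)(C)c1cc(NC(=O)Nc2ccc(Nc3ncnc4c3OCCN4)c(F)c2)no1` gives 27 nM. The step of a 1.5-fold higher number from compound 1 to compound 3 (0.17 log units; within the scatter) lies within the scatter, whereas a 3.1-fold higher number from compound 2 to compound 3 (0.50 log units; beyond the scatter) and a 2.1-fold lower number from compound 1 to compound 2 (0.33 log units; beyond the scatter) are modest but beyond it. Compound 4 `COc1cc(NC(=O)Nc2cc(C(C)(C)C)on2)ccc1Nc1ncnc2c1OCCN2` carries methoxy in place of methyl on an aromatic carbon. Among the measured compounds shown here, no measured step exchanges methyl for methoxy, so the steps that bear on it are a 1.5-fold higher number from compound 1 to compound 3 (0.17 log units; within the scatter) and a 3.1-fold higher number from compound 2 to compound 3 (0.50 log units; beyond the scatter), which show that exchanging a small group at this place moves the number only modestly. For compound 4 a step of a 1.1-fold lower number from compound 3 to compound 4 (0.05 log units; within the scatter) is therefore expected, not clearly beyond the scatter in either direction. Compound 4 is estimated at 75 nM, with a range of 30 nM to 190 nM.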

Compound 4, half-maximal inhibitory concentration: 29 nM
Estimate against measurement, compound 4: 2.6-fold (0.41 log units) above; the measured number lies below the stated range.
By their numbers in this assay, from the lowest: compounds 2, 4, 1 and 3 (each within the scatter of the next, the first and the last beyond it).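

Methoxy in place of methyl at this place gives a step beyond the scatter in this assay (a 2.9-fold lower number from compound 3 to compound 4 (0.47 log units; beyond the scatter)), which the earlier exchanges of hydrogen, fluoro and methyl did not predict. Methoxy stays within the scatter of fluoro (a 1.1-fold higher number from compound 2 to compound 4 (0.03 log units; within the scatter)) and of hydrogen (a 2.0-fold lower number from compound 1 to compound 4 (0.30 log units; within the scatter)), so among these groups only the methyl and fluoro pair and the methyl and methoxy pair are separated. Nothing measured here accounts for the gap between methyl and methoxy.

Still open is how a hydroxyl, an amine or an ethoxy group at this place would read in this assay ( the compounds shown stop at methoxy ).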